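Amide nitrogen substituent swap in the shared core series

A few compounds are considered here, and "the series" means these few. Any claim that something is new, unique, unknown or untested is made for them only; others in the source may bear on it.

Compound 1 `CC(C)(C)NC(=O)CCc1cccc2c1B(O)OC2` carries a tert-butyl group on the amide nitrogen. In a functional assay on HCT-116 cells (Homo sapiens) for antiproliferative activity, read by MTT assay, with a stated time of 72 h (a lower number here means a stronger inhibitor, a higher number a weaker inhibitor), compound 1 gives > 100000 nM, which is a limit of the assay rather than a number. Compound 2 `CC(C)(C)OC(=O)Nc1ccc(NC(=O)CCc2cccc3c2B(O)OC3)cc1` gives 24000 nM in this assay. Compound 3 `O=C(CCc1cccc2c1B(O)OC2)Nc1ccc([N+](=O)[O-])cc1` gives > 100000 nM, again a limit. Among the compounds with values here, the one step measured in a single place, an at least 4.1-fold higher number from compound 2 to compound 3 (0.61 log units; beyond the scatter), touches the aromatic ring rather than the amide nitrogen, so it bears on the present question only indirectly. Compound 2 and compound 1 differ in more than one place, so their values show only that an aryl amide reaches a number while the tert-butyl amide does not. The series is bounded by the limit of > 100000 nM in this assay, at which 2 of the 3 values shown sit.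

Compound 4 `O=C(CCc1cccc2c1B(O)OC2)Nc1cccc(Br)c1` differs from compound 1 in one place: 3-bromophenyl in place of tert-butyl on an amide-type nitrogen. Within the data shown here, no measured step covers this change directly. The aryl amide of compound 2 reaching 24000 nM is the only pointer, and the bromine-bearing ring of compound 4 carries neither of the groups compared in compound 2 and compound 3. A modest move toward a stronger inhibitor is expected, an at least 2.0-fold lower number from compound 1 to compound 4 (0.30 log units; that floor lies within the scatter). Compound 4 is estimated at 50000 nM, within 15000 nM to 150000 nM, with a fair chance that only a limit is returned.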

Compound 4, half-maximal inhibitory concentration: 1400 nM
Beside the measured number, compound 4's estimate is 36-fold (1.55 log units) above it; measured number below the stated range.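

In this assay, within the data shown here, the group on the amide-type nitrogen now has a reading in one place: 3-bromophenyl in place of tert-butyl gives an at least 71-fold lower number from compound 1 to compound 4 (1.85 log units; beyond the scatter), a large step beyond the scatter, which the earlier compounds could only hint at through structures differing in more than one place. The size of this step is a floor and not a full measured gap, because compound 1 gives only a limit of the assay and the true gap may be larger: the limit of > 100000 nM in this assay, at which 2 of the 4 values shown sit. An aromatic ring on this nitrogen does not by itself carry a measurable number, since compound 3, which goes against any such pattern, gives > 100000 nM, which is a limit of the assay.

On these data alone, it remains open whether the step rests on the six-membered aromatic ring or on its bromine, which an unsubstituted phenyl on the same nitrogen would separate. Also open, as far as these compounds go, is how a benzyl group, a cyclohexyl group or a chlorine in place of the bromine would read in this assay on the shared core.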